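The compounds below may be only part of what the source reports. "The series", "measured", "known", "first", "only" and "open" are said of these compounds alone.

Notes on the series. In an ADME assay on microsomes from liver (Rattus norvegicus) for metabolic stability (on this read-out lower numbers stand for a shorter-lived compound and higher numbers for a longer-lived compound), compound 3 `Cn1nc2c(=O)n(CC3(O)CCN(Cc4ccc(-c5cccs5)cc4Cl)CC3)cnc2c1-c1ccc(CN)cc1` gives 1.38 h, the highest number of the three measured compounds, with the gaps to both neighbours beyond the scatter. Compound 1 `Cn1nc2c(=O)n(CC3(O)CCN(Cc4ccc(-c5ccco5)cc4Cl)CC3)cnc2c1-c1ccc(C2(N)CC2)cc1` gives 0.617 h in this assay, and compound 2 `Cn1nc2c(=O)n(CC3(O)CCN(Cc4ccc(-c5ccco5)cc4Cl)CC3)cnc2c1-c1ccc(CNS(C)(=O)=O)cc1` gives 0.433 h. For the measured compounds named here, the one single-point step measured so far, a 1.4-fold lower number from compound 1 to compound 2 (0.15 log units; within the scatter), concerns a change at the other end of the molecule and says nothing about the ring at the chloro-substituted ring; compounds 1 and 2 differ from compound 3 in more than one place, so no measured step bears on the change now in question.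

Compound 4 `Cn1nc2c(=O)n(CC3(O)CCN(Cc4ccc(C5=CCCC5)cc4Cl)CC3)cnc2c1-c1ccc(CN)cc1` differs from compound 3 in one place: cyclopent-1-en-1-yl in place of thiophen-2-yl on an aromatic carbon. Going by the values given here, with no comparable step in hand, the expectation for this assay is a step of no more than the scatter, with a slight lean toward a shorter half-life given that compound 3 sits at the top of the measured range. The expected step from compound 3 to compound 4 is a 1.3-fold lower number from compound 3 to compound 4 (0.10 log units; within the scatter). Compound 4 is estimated at 1.1 h in this assay, within a range of 0.5 h to 2.5 h.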

Compound 4, half-life: 2.33 h
Compound 4: middle estimate off by 2.1-fold (0.33 log units), on the low side; measured number inside the range.
By their numbers in this assay, from the lowest: compounds 2 and 1 (each within the scatter of the next); then compounds 3 and 4 (each within the scatter of the next).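

At the aromatic carbon para to a large group and meta to a chloro group, this assay gives a 1.7-fold higher number from compound 3 to compound 4 (0.23 log units; within the scatter), so the two five-membered rings cannot be told apart on this read-out. Within this one pair, a ring of carbon only with one double bond can thus stand in place of the aromatic sulfur-containing ring with no step beyond the scatter, and the hydrogen-bond acceptor counted for thiophen-2-yl can be lost in the same way. No measurement at hand offers an explanation for this result.

As far as these compounds go, whether the tolerance extends to a saturated cyclopentyl ring, a six-membered phenyl ring or an open pentyl chain at this position remains open. From the compounds shown here alone, it is also open whether an amine on the ring would keep the half-life in the same range.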